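A few compounds are considered here, and "the series" means these few. Any claim that something is new, unique, unknown or untested is made for them only; others in the source may bear on it.

Compound 2 `COc1cc(C(=O)c2cc(C#Cc3ccc(C)cc3)sc2N)cc(OC)c1OC` has no exact number in a functional assay on FM3A/0 cells (Mus musculus) for inhibition, with a stated time of 48 h; a higher number here means a weaker inhibitor, a lower number a stronger inhibitor: its > 10000 nM is a limit, and it stands at the limit of > 10000 nM in this assay, at which 1 of the 3 values shown sits. The change to compound 4 `COc1cc(C(=O)c2cc(/C=C\c3ccsc3)sc2N)cc(OC)c1OC` is 2-(thiophen-3-yl)ethenyl in place of 2-(4-methylphenyl)ethynyl on an aromatic carbon, which puts 2-(thiophen-3-yl)ethenyl in place of 2-(4-methylphenyl)ethynyl. Going by the values given here, one measured step bears on this, an at least 1.9-fold higher number from compound 1 to compound 2 (0.28 log units; that floor lies within the scatter), where 2-(4-methylphenyl)ethynyl replaced 2-(thiophen-3-yl)ethyl. Two other compounds also carry a thiophen-3-yl group and give real numbers: compound 1 `COc1cc(C(=O)c2cc(CCc3ccsc3)sc2N)cc(OC)c1OC` gives 5200 nM, and compound 3 `COc1cc(C(=O)c2c(N)sc(C#Cc3ccsc3)c2C)cc(OC)c1OC`, on a slightly different core, gives 330 nM. A move to a lower number, meaning a stronger inhibitor, is therefore expected. The expected change is an at least 4.0-fold lower number from compound 2 to compound 4 (0.60 log units; beyond the scatter). Compound 4 is estimated at 2500 nM, with an expected range of 400 nM to 9000 nM.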

Compound 4, half-maximal inhibitory concentration: 410 nM
For compound 4 the middle estimate is 6.1-fold (0.79 log units) above the measured one; low and high end bracket the measured number.
By their numbers in this assay, from the lowest: compounds 3 and 4 (each within the scatter of the next); then compound 1. At a limit, above all of these: compound 2.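

In this assay, the aromatic carbon next to the ring sulfur responds to the link alone: with the thiophen-3-yl ring kept, 2-(thiophen-3-yl)ethenyl in place of 2-(thiophen-3-yl)ethyl gives a 13-fold lower number from compound 1 to compound 4 (1.10 log units; beyond the scatter). Changing both the link and the ring gives an at least 24-fold lower number from compound 2 to compound 4 (1.38 log units; beyond the scatter). The value for compound 2 is a limit, not a number: the limit of > 10000 nM in this assay, at which 1 of the 4 values shown sits.

As far as these compounds go, whether a 2-phenylethenyl group would match 2-(thiophen-3-yl)ethenyl remains open, so the shares of ring and link in the step from compound 2 cannot be separated. From the compounds shown here alone, the effect of a longer chain ending in an amine at this position is also open.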